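A Side-Chain Swap in a Weakly Binding Series

A few compounds are considered here, and "the series" means these few. Any claim that something is new, unique, unknown or untested is made for them only; others in the source may bear on it.

Compound 1 `Cc1cccc(NC(=O)Nc2ccc(Oc3ncnc4[nH]ncc34)cc2)c1C`: 98800 nM in an assay on isolated protein for inhibition of vascular endothelial growth factor receptor 2 (Danio rerio), read by fluorescence and microscopy, with a stated time of 33 h; a higher number here means a weaker inhibitor, a lower number a stronger inhibitor
Compound 2 `O=C(Nc1cccc(Oc2ncnc3[nH]ncc23)c1)c1ccc(C(F)(F)F)cc1`: only a limit of the assay, > 100000 nM in this assay
Compound 3 `O=C(Nc1ccc(Oc2ncnc3[nH]ncc23)cc1)c1ccc(Br)cc1`: 74700 nM in this assay

The two numbers shown sit close together: compound 1 and compound 3 lie within the scatter of each other, as the step of a 1.3-fold lower number from compound 1 to compound 3 (0.12 log units; within the scatter) shows. One of the three compounds gave only a limit of > 100000 nM in this assay, at which 1 of the 3 values shown sits, rather than a number.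

Compound 4 `CC(C)c1cccc(NC(=O)Nc2ccc(Oc3ncnc4[nH]ncc34)cc2)c1` has not yet been measured. It differs from compound 1 in one place: 3-isopropylphenyl in place of 2,3-dimethylphenyl on an amide-type nitrogen. Among the compounds with values here, the only measured step, a 1.3-fold lower number from compound 1 to compound 3 (0.12 log units; within the scatter), changed a different part of the molecule and stayed within the scatter, so no measured step speaks directly to this change. With nothing pointing either way, the expected step is a 1.0-fold higher number from compound 1 to compound 4 (0.01 log units; within the scatter), which is none beyond the scatter. For compound 4 the estimated value is 100000 nM, with a range from 40000 nM to 250000 nM.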

Compound 4, half-maximal inhibitory concentration: 7730 nM
For compound 4 the middle estimate is 13-fold (1.11 log units) above the measured one, and the stated range ends above it.
By their numbers in this assay, from the lowest: compound 4; then compounds 3 and 1 (each within the scatter of the next). At a limit, above all of these: compound 2.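

Within the data shown here, the group on the amide-type nitrogen clearly matters: the swap to 3-isopropylphenyl gives a 13-fold lower number from compound 1 to compound 4 (1.11 log units; beyond the scatter), the first step here beyond the scatter. The earlier step, made at a different part of the molecule, showed no such change. Nothing measured here explains why this swap has so large an effect.

The swap removes two methyl groups and adds an isopropyl group in one move, so the contribution of each remains unclear. On these data alone, whether a tert-butyl or methoxy group in place of the isopropyl would give a stronger or weaker inhibitor also remains open.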